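This account rests on a few compounds, and the source may have more. Where it says the series, first, only, none or still open, it means among the compounds named here.

In an ADME assay on HEK293 cells (Homo sapiens) for inhibition, read by MTT assay, with a stated time of 96 h (a higher number here means a weaker inhibitor of growth, a lower number a stronger inhibitor of growth), compound 1 `O=C(NCCCCCCSSCCCCCCNC(=O)c1cc(-c2ccncc2)n[nH]1)c1cc(-c2ccncc2)n[nH]1` gives 14800 nM and compound 2 `C=CCOC(=O)SCCCCCCNC(=O)c1cc(-c2ccncc2)n[nH]1` gives 27500 nM and these two numbers lie within the usual scatter of repeated measurements. Compound 2 therefore stands level with compound 1, and the data do not separate them. Compound 3 `CC(=O)SCCCCCCNC(=O)c1cc(-c2ccncc2)n[nH]1` keeps the rest of compound 2 but carries methyl in place of allyloxy on a carbonyl carbon. Going by the values given here, no pair of measured compounds shows what this kind of change does, so the only available anchor is compound 2 at 27500 nM in this reading. With so little evidence, the expected change is no larger than the scatter, and no firm direction can be claimed: the estimated 1.3-fold lower number from compound 2 to compound 3 (0.10 log units; within the scatter) is a small one. For compound 3 the estimated value is 22000 nM (expected range 9000 nM to 50000 nM).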

Compound 3, concentration for 50% growth inhibition: > 50000 nM
Compound 3: no number, only a limit; the forecaster's own chance of this, stated with the estimate: 10%; middle value at least 2.2-fold (0.35 log units) from the limit.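

In this assay compound 3 gives > 50000 nM, which is a limit and not a number. Methyl in place of allyloxy on this carbonyl carbon gives the first step at this position, an at least 1.8-fold higher number from compound 2 to compound 3 (0.25 log units; that floor lies within the scatter), so the change from allyloxycarbonyl to acetyl brings no sign of stronger growth inhibition, although this floor alone cannot show how large the shift really is. The reading for compound 3 therefore has no upper end: the limit of > 50000 nM in this assay, at which 1 of the 3 values shown sits.

Going by these compounds alone, with only this one change at this position, it remains open whether the oxygen of allyloxy, its double bond or its length matters. A methoxy group or an amine on the same carbonyl carbon would help to separate these possibilities.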